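This account rests on a few compounds, and the source may have more. Where it says the series, first, only, none or still open, it means among the compounds named here.

Measured so far in a functional assay on the whole organism with Rattus norvegicus as the target, at a dose of 20 mg/kg by the oral route; a higher number here means more inhibition at the dose given (going by the name of the read-out), a lower number less inhibition:
compound 1 `NC(=O)/C=C1\CCc2cc(F)cc(F)c21` gives 55%
compound 2 `CC(C)NC(=O)/C=C1\CCc2ccc(F)cc21` gives 71%

Compound 2 stands highest of the two numbers; compound 1 sits below it by a margin beyond the usual scatter. The two differ in more than one place, so the values are compared only as they stand.

Compound 3 `CON(C)C(=O)/C=C1\CCc2ccc(F)cc21` is not yet measured. It differs from compound 2 as follows: methoxy(methyl)amino in place of isopropylamino on a carbonyl carbon. The replaced group carried the only hydrogen-bond donor on that carbonyl. For the measured compounds named here, no measured pair tests this change, so the direction is open. Compound 3 is expected to show a modest drop in inhibition, estimated as a number 13 percentage points lower from compound 2 to compound 3 (beyond the scatter). Compound 3 is estimated at 58%, within a range from 35% to 80%.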

Compound 3, a percentage reported as inhibition, in the whole organism at one dose (the size of the read-out at that dose, not a potency): 14%
The estimate for compound 3 lay 44 percentage points above the measured number; the measured number lies below the stated range.
By their numbers in this assay, from the lowest: compound 3; then compound 1; then compound 2.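

Within the compounds shown, the group on the carbonyl carbon is the first single change that can be read: in this assay, methoxy(methyl)amino in place of isopropylamino gives a number 57 percentage points lower from compound 2 to compound 3 (beyond the scatter), so inhibition at this dose depends strongly on this position. The change removes a hydrogen-bond donor and adds a hydrogen-bond acceptor, but also alters the group as a whole, and these cannot be separated here. Nothing available accounts for the step. Open, from the compounds shown here alone, is whether methoxyamino, which keeps the amide hydrogen, retains the inhibition of compound 2. Also open, going by these compounds, is how a longer chain on the amide nitrogen or a carboxylic acid in place of the amide would compare.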